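Clearance notes: compound 2 to compound 3

A few compounds are considered here, and "the series" means these few. Any claim that something is new, unique, unknown or untested is made for them only; others in the source may bear on it.

In an ADME assay on microsomes from liver (Homo sapiens) for metabolic stability, read by LC-MS, using NADPH, with stated times of 5 min and 30 min, tested at 1 uM (a lower number here means slower removal, a higher number faster removal of the compound), compound 1 `CN(c1ncco1)c1cnc(NCc2c(F)ccc3c2CCO3)n2cnnc12` gives 11 mL.min-1.g-1 as its reading. Compound 2 `C[C@@H]1CC(=O)N(c2cnc(NCc3c(F)ccc4c3CCO4)n3cnnc23)C1` gives < 3 mL.min-1.g-1 as its reading, which is a limit of the assay and not a number.

Compound 3 `CN(c1ccccc1)c1cnc(NCc2c(F)ccc3c2CCO3)n2cnnc12` has methyl(phenyl)amino in place of 4-methyl-2-oxopyrrolidin-1-yl on an aromatic carbon, and the change counts as methyl(phenyl)amino in place of 4-methyl-2-oxopyrrolidin-1-yl on an aromatic carbon in full. Among the compounds with values here, the one measured step that bears on this is an at least 3.6-fold lower number from compound 1 to compound 2 (0.56 log units; beyond the scatter) with 4-methyl-2-oxopyrrolidin-1-yl in place of methyl(1,3-oxazol-2-yl)amino at the same place. That step installed the group that compound 3 gives up and removed a group that, like methyl(phenyl)amino, is a methyl-substituted amino group.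

A step of similar size in the opposite direction is therefore expected in this assay towards faster removal. The expected step is an at least 6.6-fold higher number from compound 2 to compound 3 (0.82 log units; beyond the scatter) on this estimate. For compound 3 the estimated value is 20 mL.min-1.g-1 with an expected range from 8 mL.min-1.g-1 to 50 mL.min-1.g-1 in this assay.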

Compound 3, intrinsic clearance in microsomes: 55 mL.min-1.g-1
Compound 3: the middle estimate sits 2.8-fold (0.44 log units) below what was measured; the whole stated range lies below it.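

In this assay, this position on an aromatic carbon of the shared core now shows a wide spread, as methyl(phenyl)amino in place of 4-methyl-2-oxopyrrolidin-1-yl gives an at least 18-fold higher number from compound 2 to compound 3 (1.26 log units; beyond the scatter). The new comparison with compound 1 shows that the reading also depends on the ring carried by the amino nitrogen: phenyl in place of 1,3-oxazol-2-yl gives a 5.0-fold higher number from compound 1 to compound 3 (0.70 log units; beyond the scatter), so the two methyl-substituted amino groups do not read alike, and compound 3 is removed fastest of the three compounds. The step from 4-methyl-2-oxopyrrolidin-1-yl can be read only as a minimum, since compound 2 stands at a limit of the assay and not a number: the limit of < 3 mL.min-1.g-1 in this assay, at which 1 of the 3 values shown sits.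

The compounds shown leave open whether a pyridin-2-yl ring on the same nitrogen would read closer to compound 1 or to compound 3, and whether the methyl on that nitrogen contributes to either reading. They also leave open how much of the low reading of compound 2 would remain with plain 2-oxopyrrolidin-1-yl, lacking the 4-methyl group, at this position.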